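Swapping a methoxy position on a weak growth inhibitor

The source may hold more compounds than are shown below. What is called first, only, known or untested is meant among the compounds shown, and "the series" means these compounds.

Within the data shown here, in a functional assay on HepG2 cells (Homo sapiens) for inhibition, read by MTT assay (a lower number here means a stronger inhibitor of growth, a higher number a weaker inhibitor of growth), compound 2 (`COc1ccc(C(=O)Nc2cccc(-c3cc(=O)c4c(OC)c(OC)c(OC)cc4o3)c2)cc1`) gives 22200 nM as the only actual number so far. Compound 1 (`COC(=O)c1ccc(C(=O)Nc2cccc(-c3cc(=O)c4c(OC)c(OC)c(OC)cc4o3)c2)cc1`) stands at > 100000 nM which is a limit of the assay. Compound 3 (`COc1ccccc1C(=O)Nc1cccc(-c2cc(=O)c3c(OC)c(OC)c(OC)cc3o2)c1`) differs from compound 2 by 2-methoxyphenyl in place of 4-methoxyphenyl on a carbonyl carbon with 2-methoxyphenyl in place of 4-methoxyphenyl on a carbonyl carbon. Among the measured compounds shown here, the one measured step is an at least 4.5-fold lower number from compound 1 to compound 2 (0.65 log units; beyond the scatter) and it concerns a different change, so it sets only a rough scale. No step beyond the scatter is expected, and the estimated change is a 1.4-fold higher number from compound 2 to compound 3 (0.13 log units; within the scatter) only. Compound 3 is estimated to lie between 8000 nM and 100000 nM with 30000 nM as its middle value.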

Compound 3, concentration for 50% growth inhibition: 7530 nM
Compound 3: the middle estimate sits 4.0-fold (0.60 log units) above what was measured, and the stated range ends above it.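

In this assay, 2-methoxyphenyl in place of 4-methoxyphenyl on the carbonyl carbon gives a 2.9-fold lower number from compound 2 to compound 3 (0.47 log units; beyond the scatter), so with the same atoms joined differently, the place of the methoxy on this ring alone moves the number beyond the scatter. 2-Methoxyphenyl in place of 4-(methoxycarbonyl)phenyl gives an at least 13-fold lower number from compound 1 to compound 3 (1.12 log units; beyond the scatter). The size of that second step is bounded, not exact, as it rests on a limit of the assay: the limit of > 100000 nM in this assay, at which 1 of the 3 values shown sits.

The compounds shown leave open whether an ethoxy group or an amine in place of the methoxy of the 2-methoxyphenyl would keep this gain.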